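This account rests on a few compounds, and the source may have more. Where it says the series, first, only, none or still open, it means among the compounds named here.

Compound 1 `CCOC(=O)c1sc(-c2nc3ccccc3n2C)nc1C`: in a functional assay on MCF7 cells (Homo sapiens) for cytotoxicity, read by MTT assay, with a stated time of 24 h (on this read-out lower numbers stand for stronger inhibition and higher numbers for weaker inhibition), compound 1 gives > 20000 nM, which is a limit of the assay.
Compound 2 `CCOC(=O)c1sc(-c2nc3ccccc3n2Cc2ccccc2)nc1C`: in this assay compound 2 gives > 20000 nM, again a limit.

Among the compounds with values here, compound 2 therefore stands at the limit, as do both values measured so far (the limit of > 20000 nM in this assay, at which 2 of the 2 values shown sit), and the only step, a step that the two limits leave unreadable from compound 1 to compound 2, cannot be read. Compound 3 `Cc1nc(-c2nc3ccccc3n2Cc2ccccc2)sc1C(=O)NC1CCCCC1` differs from compound 2 by cyclohexylamino in place of ethoxy on a carbonyl carbon. Within the data shown here, no measured step concerns the carbonyl carbon, so the data give no footing for the size or direction of this change in this assay. Compound 3 is expected to stay near the limit, with an estimated step of a number no higher from compound 2 to compound 3 (the limit leaves the size open). Compound 3 is thus estimated at 20000 nM, ranging from 5000 nM to 80000 nM.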

Compound 3, half-maximal inhibitory concentration: 5230 nM
Compound 3: the middle estimate sits 3.8-fold (0.58 log units) above what was measured; the range from low to high includes it.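

Within the data shown here, at the carbonyl carbon, cyclohexylamino in place of ethoxy gives the first readable change in this assay, an at least 3.8-fold lower number from compound 2 to compound 3 (0.58 log units; beyond the scatter). Compound 3 is the first compound shown with a value that is a number, so this position can shift the read-out, which the unreadable step between the earlier compounds could not show. Compound 2 gives > 20000 nM, which is a limit, so the full size of the change stays unknown: the limit of > 20000 nM in this assay, at which 2 of the 3 values shown sit.

From the compounds shown here alone, what a smaller amine such as methylamino, or a carboxylic acid, would give on this carbonyl carbon remains open. Going by these compounds, it is also open whether cyclohexylamino would have the same effect on compound 1.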